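Shifting the Ester Tail of a Catechol Nitrile

A few compounds are considered here, and "the series" means these few. Any claim that something is new, unique, unknown or untested is made for them only; others in the source may bear on it.

Of the compounds shown here, two sharing one core have so far been measured in an assay on cells for inhibition of Polyunsaturated fatty acid lipoxygenase ALOX15B (Rattus norvegicus); a higher number here means a weaker inhibitor, a lower number a stronger inhibitor. Compound 1 `CCOC(=O)/C(C#N)=C/c1ccc(O)c(O)c1` carries a short ethyl ester and gives 330 nM. Compound 2 `N#C/C(=C\c1ccc(O)c(O)c1)C(=O)OCCCCc1ccccc1` extends that ester into a longer chain ending in a benzene ring, and in this assay compound 2 gives 3590 nM. For the measured compounds named here, the only step so far, an 11-fold higher number from compound 1 to compound 2 (1.04 log units; beyond the scatter), shows that lengthening the ester tail weakened inhibition considerably. Compound 2 therefore stands at the weaker end of the two numbers measured.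

Compound 3 `N#C/C(=C\c1ccc(O)c(O)c1)C(=O)OCCCc1cccnc1` is the next structure to be measured. Relative to compound 2 the change is pyridin-3-yl in place of benzyl on a saturated chain carbon, three bonds along the chain from an oxygen next to a carbonyl group: the chain shortens by one carbon and the benzene becomes a pyridine. Going by the values given here, no measured step speaks to the exchange of a benzene ring for a pyridine, and the one step recorded, an 11-fold higher number from compound 1 to compound 2 (1.04 log units; beyond the scatter), concerns chain length rather than ring identity. On that basis compound 3 is expected to land close to compound 2, with a 1.4-fold lower number from compound 2 to compound 3 (0.16 log units; within the scatter) probably not beyond the scatter. The estimate for compound 3 in this assay is 2500 nM, within a range from 900 nM to 7000 nM.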

Compound 3, half-maximal inhibitory concentration: 3930 nM
Compound 3: middle estimate off by 1.6-fold (0.20 log units), on the low side; the measured number falls inside the stated range.
By their numbers in this assay, from the lowest: compound 1; then compounds 2 and 3 (each within the scatter of the next).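

In this assay, pyridin-3-yl in place of benzyl gives a 1.1-fold higher number from compound 2 to compound 3 (0.04 log units; within the scatter), so at this place on the ester tail, a saturated chain carbon three bonds along the chain from an oxygen next to a carbonyl group, compound 2 and compound 3 cannot be told apart, even though the ring gains a nitrogen counted as a hydrogen-bond acceptor. The large step seen before is therefore not confined to a tail ending in benzene: the pyridine-bearing tail shows a 12-fold higher number from compound 1 to compound 3 (1.08 log units; beyond the scatter), a step of the same large kind as an 11-fold higher number from compound 1 to compound 2 (1.04 log units; beyond the scatter), and neither of the two tails measured so far goes against this. Nothing measured here explains the lack of a visible difference between these two tails or their large distance from the ethyl ester of compound 1.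

As far as these compounds go, the shorter chain and the new ring arrive together in compound 3, so what each does alone stays unknown. Also open, from the compounds shown here alone, is whether a tail ending in an amine or a carboxylic acid, or a longer chain with no ring, would sit nearer compound 1 or nearer compound 2 and compound 3.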